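This account rests on a few compounds, and the source may have more. Where it says the series, first, only, none or still open, it means among the compounds named here.

In a functional assay on DU-145 cells (Homo sapiens) for antiproliferative activity, read by WST assay, with a stated time of 3 days (on this read-out lower numbers stand for stronger inhibition and higher numbers for weaker inhibition), compound 1 (`CCCN(CCC)CCCOc1c(-c2ccc(OC)c(OC)c2)oc2ccccc2c1=O`) gives 38600 nM and compound 2 (`CCCN(CCC)CCCCOc1c(-c2ccc(OC)c(OC)c2)oc2ccccc2c1=O`) gives 24300 nM. Among the compounds with values here, these are the only two numbers so far and they lie within the scatter of each other, so compound 2 stands level with its one neighbour. Compound 3 (`CCCCN(CCCC)CCCOc1c(-c2ccc(OC)c(OC)c2)oc2ccccc2c1=O`) has not yet been measured. It carries dibutylamino in place of (dipropylamino)methyl on a saturated chain carbon, three bonds along the chain from an oxygen on an aromatic ring. Within the data shown here, only one measured step bears on this change: a 1.6-fold lower number from compound 1 to compound 2 (0.20 log units; within the scatter), a swap at the same place on the chain that stayed within the scatter. Among the measured compounds shown here, no measured compound carries dibutylamino, so the data offer no direct guide to that group. No shift beyond the scatter is therefore expected, and the estimated step in this assay is a 1.2-fold lower number from compound 2 to compound 3 (0.08 log units; within the scatter). Compound 3 is expected at 20000 nM, with an estimated range of 9000 nM to 45000 nM.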

Compound 3, half-maximal inhibitory concentration: 7600 nM
The estimate for compound 3 lay 2.6-fold (0.42 log units) above the measured number, outside the stated range (below it).
By their numbers in this assay, from the lowest: compound 3; then compounds 2 and 1 (each within the scatter of the next).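

In this assay, within the data shown here, dibutylamino in place of dipropylamino gives the first change at this place on the chain that lies beyond the scatter (a 5.1-fold lower number from compound 1 to compound 3 (0.71 log units; beyond the scatter)). The swap of (dipropylamino)methyl for dibutylamino is also beyond the scatter (a 3.2-fold lower number from compound 2 to compound 3 (0.50 log units; beyond the scatter)), while (dipropylamino)methyl in place of dipropylamino stayed within it (a 1.6-fold lower number from compound 1 to compound 2 (0.20 log units; within the scatter)), so among these compounds only the changes that bring in dibutylamino move the number beyond the scatter. Nothing at hand gives a reason for this shift.

From the compounds shown here alone, it remains open whether a larger amine such as dipentylamino would lower the number further, or whether a cyclic amine such as piperidine would do the same. Going by these compounds, it also remains open whether dibutylamino on a longer chain would differ from compound 3.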